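The source may report more compounds than this note shows. Statements on the series, on what has been measured and on what is new or still open speak of the compounds shown alone.

Compound 1: `COc1ccc(NC(=O)Nc2cc(C)nc3ccccc23)cc1F` — in an ADME assay on HepG2 cells (Homo sapiens) for cytotoxicity, with a stated time of 72 h (a higher number here means that more compound is needed for the effect, a lower number that less compound is needed), compound 1 gives > 25000 nM, which is a limit of the assay rather than a number.
Compound 2: `Cc1cc(NC(=O)Nc2ccc(N)cc2)c2ccccc2n1` — compound 2 gives > 25000 nM, again a limit of the assay.
Compound 3: `Cc1cc(NC(=O)Nc2cccc(C(N)=O)c2)c2ccccc2n1` — compound 3 gives > 25000 nM, also a limit of the assay.

All three measured ureas share the core of compound 2 and differ only in the substituted phenyl ring on the far side of the urea. None of them yields a numerical half-maximal effective concentration in this assay; every value stops at the limit. Compound 2 therefore stands exactly where the other two stand, at the limit described by the limit of > 25000 nM in this assay, at which 3 of the 3 values shown sit, and nothing in the data separates it from compound 1 or compound 3.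

The next compound, compound 4, is `Cc1cc(NC(=O)Nc2ccc(Cl)cc2)c2ccccc2n1`. Against compound 2 the change is chloro in place of amino on an aromatic carbon. Going by the values given here, no step between measured compounds exists here, so the size of this change can only be expected, not read off: the expectation is for little or no movement beyond the scatter in this assay, with the value most likely staying at the limit. Compound 4 is thus estimated at 30000 nM, within a range from 8000 nM to 100000 nM. The corresponding expected step is a step that the limit leaves unreadable from compound 2 to compound 4.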

Compound 4, half-maximal effective concentration: > 25000 nM
Compound 4 gave a limit, no number (the forecaster's own chance of this, stated with the estimate: 65%); the middle value lies beyond the limit too.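

Compound 4, like compound 2, sits at a limit in this assay, so the exchange of amino for chloro gives no readable step between compound 2 and compound 4: the limit of > 25000 nM in this assay, at which 4 of the 4 values shown sit.

The compounds shown leave open how far any of these ureas lies beyond that limit, and whether the changes on the phenyl ring alter the value at all.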